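The source may report more compounds than this note shows. Statements on the series, on what has been measured and on what is new or still open speak of the compounds shown alone.

Measured compounds:
- compound 1 `Cc1ccc(N2CCN(C(=O)[C@@H]3CN(C4CCOCC4)C[C@H]3c3ccc(Cl)cc3)CC2)c([C@@H](NC(=O)CCN)C(C)C)c1`: 107%
- compound 2 `Cc1ccc(N2CCN(C(=O)[C@@H]3CNC[C@H]3c3ccc(Cl)cc3)CC2)c([C@@H](NC(=O)CCN(C)C)C(C)C)c1`: 72%
- compound 3 `Cc1ccc(N2CCN(C(=O)[C@@H]3CN(C4CCOCC4)C[C@H]3c3ccc(Cl)cc3)CC2)c([C@@H](NC(=O)CN)C(C)C)c1`: 114%

In a functional assay on CHO cells with Melanocortin receptor 4 (Homo sapiens) as the target, read by cAMP accumulation (a higher number here means a larger maximal response, a lower number a smaller maximal response), compound 1 stands second highest of the three numbers. Compound 3 is the nearest to it, and the step of a number 7 percentage points higher from compound 1 to compound 3 (within the scatter) is within the usual scatter, so the two cannot be told apart. Compound 2 is furthest away, and its value in this assay lies beyond the scatter below that of compound 1.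

Compound 4 `Cc1ccc(N2CCN(C(=O)[C@@H]3CN(C4CCOCC4)C[C@H]3c3ccc(Cl)cc3)CC2)c([C@@H](NC(=O)[C@H](C)N)C(C)C)c1` keeps everything of compound 1 except one spot: 1-aminoethyl in place of 2-aminoethyl on a carbonyl carbon. The same atoms are present, joined differently, at the carbonyl carbon whose other neighbour is an amide-type nitrogen.

Among the compounds with values here, only one measured step bears on this position: the step from compound 1 to compound 3, which also rearranges the short aminoalkyl chain on that carbonyl carbon and gives a number 7 percentage points higher from compound 1 to compound 3 (within the scatter), a change within the scatter. On that basis the step of no change at the digits printed from compound 1 to compound 4 (within the scatter) is expected to stay within the scatter as well. Compound 4 is therefore estimated at 107% in this assay, with a likely range from 90% to 122%.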

Compound 4, intrinsic activity: the largest response reached, in percent of the reference agonist's: 38%
The estimate for compound 4 lay 69 percentage points above the measured number; the whole stated range lies above it.
By their numbers in this assay, from the lowest: compound 4; then compound 2; then compounds 1 and 3 (each within the scatter of the next).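

Within the data shown here, the position on the carbonyl carbon is far less forgiving than the earlier compounds suggested. Changing 2-aminoethyl to 1-aminoethyl keeps the same atoms yet gives a number 69 percentage points lower from compound 1 to compound 4 (beyond the scatter) in this assay, so the way the chain is joined matters, not just its atoms. Likewise, methyl in place of hydrogen on the saturated chain carbon bound to an amine nitrogen and a carbonyl carbon gives a number 76 percentage points lower from compound 3 to compound 4 (beyond the scatter), a large effect from one small added group, and no measurement available here explains this loss of maximal response.

Compound 4 carries one defined stereocentre, so the 1-aminoethyl group with the opposite arrangement at that carbon would show whether the loss depends on that arrangement. An ethyl or a second methyl on that same carbon would show how the response changes with larger groups there.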